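Trading propoxy for methyl on the shared core

The source may report more compounds than this note shows. Statements on the series, on what has been measured and on what is new or still open speak of the compounds shown alone.

Compound 2 `CCCOc1cc(C(=O)Nc2nn[nH]n2)nc(-c2ccccc2)c1` gives 100% in a functional assay on the whole organism with Rattus norvegicus as the target, at a dose of 3 mg/kg by the oral route (on this read-out lower numbers stand for a weaker effect and higher numbers for a stronger effect at the one dose given), the highest of the three numbers; compound 1 `COc1cc(C(=O)Nc2nn[nH]n2)nc(-c2ccccc2)c1` gives 97%, within the scatter of compound 2, and compound 3 `CCCOc1cc(C(=O)Nc2nn[nH]n2)nc(-c2ccc(N)cc2)c1` gives 68%. Compound 4 `Cc1cc(C(=O)Nc2nn[nH]n2)nc(-c2ccccc2)c1` differs from compound 2 by methyl in place of propoxy on an aromatic carbon. For the measured compounds named here, the only step at this place is a number 3 percentage points higher from compound 1 to compound 2 (within the scatter), where a longer chain on the oxygen left the read-out within the scatter. The step of a number 32 percentage points lower from compound 2 to compound 3 (beyond the scatter) concerns a different place. Going by the values given here, no measured step removes the oxygen itself, so the footing is loose. On it the expected step is a number 15 percentage points lower from compound 2 to compound 4 (beyond the scatter), near the scatter. The estimate for compound 4 is 85%, between 55% and 100%.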

Compound 4, a percentage reported as inhibition, in the whole organism at one dose (the size of the read-out at that dose, not a potency): 50%
Estimate against measurement, compound 4: 35 percentage points above, outside the stated range (below it).
By their numbers in this assay, from the lowest: compound 4; then compound 3; then compounds 1 and 2 (each within the scatter of the next).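

In this assay, for the compounds shown here, this position turns out to be far less forgiving than the earlier compounds suggested: lengthening the chain on the oxygen changed little, but methyl in place of propoxy gives a number 50 percentage points lower from compound 2 to compound 4 (beyond the scatter) and methyl in place of methoxy gives a number 47 percentage points lower from compound 1 to compound 4 (beyond the scatter) in the same read-out. Among these three compounds the read-out follows whether an oxygen sits on this carbon, not how long the chain is. Nothing measured here gives a reason for the drop. On these data alone, whether an amine or a propyl chain joined directly through carbon would hold the read-out stays open, as does the effect of a longer chain on the oxygen.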